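Shortening the hydroxamate linker on the coumarin-type core

The source may hold more compounds than are shown below. What is called first, only, known or untested is meant among the compounds shown, and "the series" means these compounds.

Measured compounds:
compound 1, `CC(C)CCc1c(OCCCCCCCC(=O)NO)ccc2ccc(=O)oc12`: 2190 nM
compound 2, `CC(C)CCc1c(OCCCCCC(=O)NO)ccc2c1OC(=O)CC2`: > 30000 nM

For the measured compounds named here, in a functional assay on A549 cells (Homo sapiens) for antiproliferative activity, read by sulforhodamine B assay, with a stated time of 48 h (a higher number here means a weaker inhibitor of growth, a lower number a stronger inhibitor of growth), compound 1 gives 2190 nM, the only numeric value in the set. For compound 2, the reading of > 30000 nM in this assay is a limit of the measurement and not a number. Going by the values given here, compound 1 therefore stands alone as the one compound with a measured potency; compound 2 differs from it in more than one place, so only their two values can be compared, and they show compound 2 sitting at the limit of > 30000 nM in this assay, at which 1 of the 2 values shown sits.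

Compound 3, `CC(C)CCc1c(OCCCCC(=O)NO)ccc2ccc(=O)oc12`, is not yet measured in this assay. It differs from compound 1 by hydroxycarbamoyl in place of 3-(hydroxycarbamoyl)propyl on a saturated chain carbon, four bonds along the chain from an oxygen on an aromatic ring. Both compounds keep the same core, and the hydroxycarbamoyl group is retained.

Among the compounds with values here, with no single-point step measured, the expectation rests on compound 1 and the structural change. Compound 3 is expected to lose potency, a step of a 6.8-fold higher number from compound 1 to compound 3 (0.84 log units; beyond the scatter) in this assay, partly because compound 2 shows (the limit of > 30000 nM in this assay, at which 1 of the 2 values shown sits). The estimate for compound 3 is 15000 nM, in the range 4000 nM to 30000 nM.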

Compound 3, concentration for 50% growth inhibition: 2760 nM
Beside the measured number, compound 3's estimate is 5.4-fold (0.74 log units) above it; the measured number lies below the stated range.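

The step in this assay reads a 1.3-fold higher number from compound 1 to compound 3 (0.10 log units; within the scatter), so compound 1 and compound 3 cannot be told apart here. For the compounds shown here, this is the first comparison in the set that differs in one place only: with the shared core and the hydroxycarbamoyl group kept, 3-(hydroxycarbamoyl)propyl and hydroxycarbamoyl on a saturated chain carbon, four bonds along the chain from an oxygen on an aromatic ring, give readings within the scatter of each other. Compound 2 remains the only compound whose reading is a limit, and since it differs from compound 1 and from compound 3 in more than one place, chain length alone cannot be tied to that reading: the limit of > 30000 nM in this assay, at which 1 of the 3 values shown sits.

The compounds shown leave open how far this tolerance extends, whether a chain shorter than that of compound 3 or longer than that of compound 1 would read the same, and how either chain would read on the core of compound 2. They also leave open what a carboxylic acid or a primary amide would give in place of the hydroxycarbamoyl group at the end of the chain.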